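Hydroxy to 2-aminophenyl on the terminal amide nitrogen

The source may hold more compounds than are shown below. What is called first, only, known or untested is meant among the compounds shown, and "the series" means these compounds.

Measured so far:
compound 1 `Cn1cc(-c2ccccc2Oc2ccccc2)c2cc(C(=O)NCCCC(=O)NO)[nH]c2c1=O`: 144 nM
compound 2 `Cn1cc(-c2ccccc2Oc2ccccc2)c2cc(C(=O)NCCCCCCC(=O)NO)[nH]c2c1=O`: 4.7 nM

Compound 2 holds the lowest of the two numbers in an assay on isolated protein for inhibition of protein deacetylase HDAC6 (Homo sapiens), read by fluorescence; a higher number here means a weaker inhibitor, a lower number a stronger inhibitor; compound 1 stands a 31-fold lower number from compound 1 to compound 2 (1.49 log units; beyond the scatter) away. Compound 3 `Cn1cc(-c2ccccc2Oc2ccccc2)c2cc(C(=O)NCCCCCCC(=O)Nc3ccccc3N)[nH]c2c1=O` differs from compound 2 by 2-aminophenyl in place of hydroxy on an amide-type nitrogen. Within the data shown here, the one measured step, from compound 1 to compound 2, changed only the chain and so gives no direct guide to this change; nothing measured here speaks to what replacing the hydroxy does. The step is expected to be a 1100-fold higher number from compound 2 to compound 3 (3.03 log units; beyond the scatter), a rise beyond the scatter. Compound 3 is estimated at 5000 nM, within 500 nM to 50000 nM.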

Compound 3, half-maximal inhibitory concentration: > 500 nM
Compound 3: a limit, no number; the forecaster's own chance of this, stated with the estimate: 25%; the middle value is on the limit's open side.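

In this assay compound 3 gives > 500 nM, a limit of the assay and not a number. With 2-aminophenyl in place of hydroxy on the amide-type nitrogen, the data show an at least 100-fold higher number from compound 2 to compound 3 (2.02 log units; beyond the scatter). Among these compounds, the earlier compounds differed only in the chain and all carried hydroxy there, so this is the first evidence that the group on this nitrogen itself matters in this assay.

Going by these compounds, how far compound 3 lies past its limit stays open. So does what a methoxy group or a plain phenyl on that nitrogen would give, or 2-aminophenyl on the shorter chain of compound 1.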